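The source may report more compounds than this note shows. Statements on the series, on what has been measured and on what is new or still open speak of the compounds shown alone.

Two compounds share one core and differ only in the group on the saturated chain carbon bound to the amine nitrogen. Compound 1 `CC[C@@H](C)[C@H](N)CN(C(=O)[C@@H]1C[C@H]1c1ccccc1)c1ccc(-c2ccccc2)cc1` carries a sec-butyl there, and in a functional assay for agonist activity at G protein-coupled receptor 88 (Homo sapiens), read by HTRF and cAMP accumulation (a lower number here means that less compound is needed, a higher number that more compound is needed for the effect), compound 1 gives 1.4 nM. Compound 2 `CC(C)(C)[C@H](N)CN(C(=O)[C@@H]1C[C@H]1c1ccccc1)c1ccc(-c2ccccc2)cc1` carries a tert-butyl instead, and in this assay compound 2 gives 11 nM, the higher of the two numbers; the step of a 7.9-fold higher number from compound 1 to compound 2 (0.90 log units; beyond the scatter) shows that this region matters. Compound 3 `O=C([C@@H]1C[C@H]1c1ccccc1)N(CC1CCCNC1)c1ccc(-c2ccccc2)cc1` is changed further: piperidin-3-yl in place of 1-amino-2,2-dimethylpropyl on a saturated chain carbon bound to an amide-type nitrogen. Within the data shown here, no measured step covers this change, so the expectation rests on the sensitivity seen so far; a modest rise beyond the scatter is expected, a 3.6-fold higher number from compound 2 to compound 3 (0.56 log units; beyond the scatter), giving compound 3 an estimated 40 nM, within 8 nM to 300 nM.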

Compound 3, half-maximal effective concentration: 10 nM
Estimate against measurement, compound 3: 4.0-fold (0.60 log units) above; measured number inside the range.
By their numbers in this assay, from the lowest: compound 1; then compounds 3 and 2 (each within the scatter of the next).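

Ring closure need not cost anything at this position: in this assay the change to piperidin-3-yl gives a 1.1-fold lower number from compound 2 to compound 3 (0.04 log units; within the scatter) and so cannot be told apart from the 1-amino-2,2-dimethylpropyl group. The same ring still gives a 7.1-fold higher number from compound 1 to compound 3 (0.85 log units; beyond the scatter) when set against the 1-amino-2-methylbutyl group, leaving compound 1 with the lowest number of the three. Nothing available explains these numbers. Still open, as far as these compounds go, is how much the ring size and the place of its nitrogen matter. A pyrrolidin-3-yl or piperidin-4-yl group on the same carbon would test this.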